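The compounds below may be only part of what the source reports. "The series", "measured", "known", "first", "only" and "open" are said of these compounds alone.

Measured compounds:
compound 1 `CC1CCN(c2c(S(=O)(=O)c3ccc(F)c(Cl)c3)cnc3cc(Cl)ccc23)CC1`, an assay on isolated protein for displacement of a labelled ligand from metabotropic glutamate receptor 5 (Homo sapiens), with a stated time of 60 min, tested at 1 uM (on this read-out higher numbers stand for more inhibition at the one concentration tested (going by the name of the read-out) and lower numbers for less inhibition), 94%
compound 2 `CC1CCN(c2c(S(=O)(=O)c3ccccc3)cnc3cc(Cl)ccc23)CC1`, this assay 93%
compound 3 `CC1CCN(c2c(S(=O)(=O)c3ccc(F)c(Cl)c3)cnc3ccc(F)cc23)CC1`, this assay 95%

Compounds 1 and 2 share a core and differ by one change, (phenyl in place of 3-chloro-4-fluorophenyl on a sulfonyl sulfur). The step of a number 1 percentage points lower from compound 1 to compound 2 (within the scatter). Compound 3 carries a different core; the difference between the two cores from compound 1 to compound 3 is not broken down here, and the two values lie within the scatter of each other.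

Compound 4 `CC1CCN(c2c(S(=O)(=O)c3ccccc3)cnc3ccc(F)cc23)CC1` is not yet measured. It is obtained from compound 3 by phenyl in place of 3-chloro-4-fluorophenyl on a sulfonyl sulfur, the same change as from compound 1 to compound 2, made at the same place. Because compound 1 to compound 2 gave a number 1 percentage points lower from compound 1 to compound 2 (within the scatter), a step of similar size is expected here: a number 2 percentage points lower from compound 3 to compound 4 (within the scatter). The estimate for compound 4 in this assay is 93%, with a range from 85% to 98%.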

Compound 4, a percentage reported as inhibition, at one concentration (the size of the read-out at that concentration, not a potency): 40%
The estimate for compound 4 lay 53 percentage points above the measured number, outside the stated range (below it).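

On the core of compound 3, phenyl in place of 3-chloro-4-fluorophenyl on a sulfonyl sulfur gives a number 55 percentage points lower from compound 3 to compound 4 (beyond the scatter) in this assay. The change therefore does not carry over unchanged between these two cores: the same change on two cores in this assay, a number 1 percentage points lower (within the scatter) from compound 1 to compound 2 and a number 55 percentage points lower (beyond the scatter) from compound 3 to compound 4, 54 percentage points apart, beyond the scatter of two such steps
With one pair on each core, this shows that the size of the step depends on the core in these four compounds, but not which difference between the cores matters or how the change would behave on a further core.

Open, as far as these compounds go, is whether the chlorine, the fluorine or both account for the step on the core of compound 3, which a phenyl bearing only one of these halogens would separate. Also open, from the compounds shown here alone, is how a phenyl bearing a methoxy or nitrile group would read on each core.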